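The source may report more compounds than this note shows. Statements on the series, on what has been measured and on what is new or still open speak of the compounds shown alone.

Of the compounds shown here, two sharing one core have been measured in a functional assay on NCI-H460 cells (Homo sapiens) for inhibition, read by MTT assay, with a stated time of 24 h, tested at 10 ug/mL; a lower number here means less inhibition of growth, a higher number more inhibition of growth at the concentration tested. Compound 1 `O=C(CCCCC(S)CCS)Nc1ccc(Cl)cc1` gives 22%, and compound 2 `O=C(CCCCC(S)CCS)Nc1ccc(F)cc1` gives 18.1%. The step of a number 3.9 percentage points lower from compound 1 to compound 2 (within the scatter) replaces chloro with fluoro on an aromatic carbon and lies within the scatter, so compound 2 cannot be separated from compound 1 on these numbers.

Compound 3 `COc1ccc(NC(=O)CCCCC(S)CCS)cc1` departs from compound 2 by a single change: methoxy in place of fluoro on an aromatic carbon. In words, methoxy stands in place of fluoro on an aromatic carbon, para to a large group.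

Among the measured compounds shown here, only one measured step bears on this change, and it is an exchange at the same place on the ring. For the measured compounds named here, no measured step involves methoxy, so the evidence is indirect and the range must stay wide. Since a number 3.9 percentage points lower from compound 1 to compound 2 (within the scatter) stayed within the scatter, no step beyond the scatter is expected in this assay, and no direction is favoured. The expected change is a number 1.9 percentage points higher from compound 2 to compound 3 (within the scatter). For compound 3 the estimated value is 20%, with an expected range from 8% to 34%.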

Compound 3, percent growth inhibition at one concentration: 1.43%
Compound 3: the middle estimate sits 18.6 percentage points above what was measured; measured number outside the range, below it.
By their numbers in this assay, from the lowest: compound 3; then compounds 2 and 1 (each within the scatter of the next).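

In this assay, the aromatic carbon para to a large group proves not to be indifferent to what it carries: methoxy in place of fluoro gives a number 16.7 percentage points lower from compound 2 to compound 3 (beyond the scatter), and methoxy in place of chloro gives a number 20.6 percentage points lower from compound 1 to compound 3 (beyond the scatter). The earlier exchange of one halogen for the other had stayed within the scatter, so compound 1 and compound 2 remain together, and compound 3, with methoxy, is the one that separates from both, showing less inhibition of growth at the concentration tested. Nothing measured here says why methoxy departs from the two halogens in this way.

The compounds shown leave open whether this low number belongs to methoxy alone or would also appear with another group on this carbon, such as an amine, a hydroxyl or the longer ethoxy. They also leave open whether the same exchange would give a step of similar size if the rest of the shared core were altered, for instance with a shorter chain on the carbonyl side of the amide.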